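This account rests on a few compounds, and the source may have more. Where it says the series, first, only, none or still open, it means among the compounds named here.

Of the compounds shown here, three share one core and have been tested in a functional assay on NCI-H460 cells (Homo sapiens) for cytotoxicity, read by MTT assay, with a stated time of 72 h; on this read-out lower numbers stand for stronger inhibition and higher numbers for weaker inhibition. Compound 1 `CC1CCN(Cc2ccc3nc(NC(=O)N/N=C/c4cn(Cc5cccc(Cl)c5)c5ccccc45)sc3c2)CC1` gives 280 nM. Compound 2 `Cc1ccc(Cn2cc(/C=N/NC(=O)Nc3nc4ccc(CN5CCC(C)CC5)cc4s3)c3ccccc32)cc1` gives 410 nM. Compound 3 `CCN(CC)Cc1ccc2nc(NC(=O)N/N=C/c3cn(Cc4ccccc4)c4ccccc34)sc2c1` gives 450 nM. For the measured compounds named here, the one single-point step measured, a 1.5-fold higher number from compound 1 to compound 2 (0.17 log units; within the scatter), changed only the group on the saturated chain carbon bound to the aromatic nitrogen. Of the three numbers, that of compound 3 is the largest, yet its gaps to compound 2 and to compound 1 both lie within the scatter, so the three sit in one narrow band.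

Compound 4 `CC1CCN(Cc2ccc3nc(NC(=O)N/N=C/c4cn(Cc5ccccc5)c5ccccc45)sc3c2)CC1` is not yet measured. It differs from compound 3 in one place: 4-methylpiperidin-1-yl in place of diethylamino on a saturated chain carbon bound to an aromatic carbon. Going by the values given here, no measured step alters this amine, so nothing directly tells how this change reads. Compound 1 and compound 2 carry the same 4-methylpiperidin-1-yl group and their numbers stay close to that of compound 3; on that basis no step beyond the scatter is expected, and compound 4 is estimated at 350 nM, within 150 nM to 800 nM. The expected step is a 1.3-fold lower number from compound 3 to compound 4 (0.11 log units; within the scatter).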

Compound 4, half-maximal inhibitory concentration: 1910 nM
Compound 4: middle estimate off by 5.5-fold (0.74 log units), on the low side; the measured number lies above the stated range.
By their numbers in this assay, from the lowest: compounds 1, 2 and 3 (each within the scatter of the next); then compound 4.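

In this assay, the amine on the saturated chain carbon bound to an aromatic carbon proves not to be a neutral choice: 4-methylpiperidin-1-yl in place of diethylamino gives a 4.2-fold higher number from compound 3 to compound 4 (0.63 log units; beyond the scatter) and so moves the number beyond the scatter. With 4-methylpiperidin-1-yl held fixed, the small group on the aromatic ring of the benzyl part also counts, since hydrogen in place of methyl gives a 4.7-fold higher number from compound 2 to compound 4 (0.67 log units; beyond the scatter) and hydrogen in place of chloro gives a 6.8-fold higher number from compound 1 to compound 4 (0.83 log units; beyond the scatter) with both steps beyond the scatter. Nothing measured here explains these steps.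

As far as these compounds go, whether chloro or methyl would have a similar effect alongside diethylamino stays open. So does how a morpholin-4-yl amine, or a methoxy group on that aromatic ring, would read.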